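Fluoro in Place of Chloro on the Dichlorophenyl Group

A few compounds are considered here, and "the series" means these few. Any claim that something is new, unique, unknown or untested is made for them only; others in the source may bear on it.

Of the compounds shown here, three built on one shared core have been measured in an assay for displacement of a labelled ligand from melanin-concentrating hormone receptor 1 (Homo sapiens), read by fluorescence; a lower number here means a stronger inhibitor, a higher number a weaker inhibitor. Compound 1 `CC(=O)Nc1cccc(C2CCN(CCCn3c(-c4ccccc4)nc4ccccc43)CC2)c1` gives 2 nM, compound 2 `CC(=O)Nc1cccc(C2CCN(CCCn3c(-c4ccccc4Cl)nc4ccccc43)CC2)c1` gives 10 nM, and compound 3 `CC(=O)Nc1cccc(C2CCN(CCCn3c(-c4ccc(Cl)cc4Cl)nc4ccccc43)CC2)c1` gives 3 nM. Compound 3 thus stands second highest of the three numbers, close to compound 1 and apart from compound 2, as the steps of a 1.5-fold higher number from compound 1 to compound 3 (0.18 log units; within the scatter) and a 3.3-fold lower number from compound 2 to compound 3 (0.52 log units; beyond the scatter) show. Compound 4 `CC(=O)Nc1cccc(C2CCN(CCCn3c(-c4ccc(Cl)cc4F)nc4ccccc43)CC2)c1` differs from compound 3 by fluoro in place of chloro on an aromatic carbon. Going by the values given here, the steps that bear on this are a 5.0-fold higher number from compound 1 to compound 2 (0.70 log units; beyond the scatter) and a 3.3-fold lower number from compound 2 to compound 3 (0.52 log units; beyond the scatter); both change the same ring, yet neither exchanges chloro for fluoro, so their bearing is indirect. Only a small step, no change at the digits printed from compound 3 to compound 4 (within the scatter), is expected, within the scatter. Compound 4 is therefore estimated at 3 nM, between 1 nM and 9 nM.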

Compound 4, half-maximal inhibitory concentration: 1 nM
Compound 4: the middle estimate sits 3.0-fold (0.48 log units) above what was measured, within the range that was stated.
By their numbers in this assay, from the lowest: compounds 4, 1 and 3 (each within the scatter of the next, the first and the last beyond it); then compound 2.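

In this assay, going by these compounds alone, the position ortho to a large group, earlier seen only with hydrogen or chloro, proves sensitive to which halogen it carries, since fluoro in place of chloro gives a step beyond the scatter (a 3.0-fold lower number from compound 3 to compound 4 (0.48 log units; beyond the scatter)). The 4-chloro-2-fluorophenyl group also stands well clear of the 2-chlorophenyl group (a 10-fold lower number from compound 2 to compound 4 (1.00 log units; beyond the scatter)) yet stays within the scatter of plain phenyl (a 2.0-fold lower number from compound 1 to compound 4 (0.30 log units; within the scatter)). No measurement shown here explains the gap between the two halogens.

The compounds shown leave open how a methoxy group or an amine would read at this position. They also leave open whether fluoro there gives a similar result without the chloro group.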